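The source may hold more compounds than are shown below. What is called first, only, known or untested is meant among the compounds shown, and "the series" means these compounds.

Measured so far in an ADME assay on microsomes from liver (Homo sapiens) for metabolic stability; on this read-out higher numbers stand for fast clearance and lower numbers for slow clearance:

- Compound 1 `CCCC(Oc1ccc(-n2cc(C(=O)N(C)C)cn2)cc1)c1ccc(C(=O)NCCC(=O)O)cc1`: < 13 mL/min/kg
- Compound 2 `CCCC(Oc1ccc(-n2cc(F)cn2)cc1)c1ccc(C(=O)NCCC(=O)O)cc1`: 12 mL/min/kg

The entry for compound 1, < 13 mL/min/kg, is a limit of the assay and not a number. Within the data shown here, that leaves compound 2, at 12 mL/min/kg, as the only true number available, and the two compounds share the same core.

Compound 3 `CCCC(Oc1ccc(-n2cc(Cl)cn2)cc1)c1ccc(C(=O)NCCC(=O)O)cc1` departs from compound 2 in one substituent: chloro in place of fluoro on an aromatic carbon. This is chloro in place of fluoro on an aromatic carbon, and the group is the 4-fluoro-1H-pyrazol-1-yl to 4-chloro-1H-pyrazol-1-yl exchange. Among the measured compounds shown here, the only measured step at this substituent is a step that the limit leaves unreadable from compound 1 to compound 2, so it gives no size to scale from, and the limit of < 13 mL/min/kg in this assay, at which 1 of the 2 values shown sits, is all that can be said of it.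

With no readable step as a guide, the expectation rests on compound 2 at 12 mL/min/kg, and no change beyond the usual scatter is expected in this assay, in either direction. The estimated change is a 1.2-fold higher number from compound 2 to compound 3 (0.07 log units; within the scatter). For compound 3 the expected clearance is 14 mL/min/kg, with an estimated range of 8 mL/min/kg to 25 mL/min/kg.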

Compound 3, clearance in the Homo sapiens assay: 10 mL/min/kg
Beside the measured number, compound 3's estimate is 1.4-fold (0.15 log units) above it; low and high end bracket the measured number.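

Among these compounds, in the Homo sapiens assay the exchange of 4-fluoro-1H-pyrazol-1-yl for 4-chloro-1H-pyrazol-1-yl provides the first readable step at this position, a 1.2-fold lower number from compound 2 to compound 3 (0.08 log units; within the scatter), and on clearance the two halogens do not separate. In a physicochemical assay for lipophilicity, using the shake flask method, at pH 7.4 (a lower number here means a more polar compound, a higher number a more lipophilic compound), compound 2 gives 2 and compound 3 gives 2.6, so the same exchange does move the read-out: the measured distribution coefficient of compound 2, 2, and of compound 3, 2.6, a number 0.60 log units higher (beyond the scatter) On this one pair, therefore, a distribution coefficient that shifts beyond the scatter goes together with a clearance that stays within it, and this observation extends no further than compound 2 and compound 3.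

On these data alone, compound 1 carries a limit of the assay and not a number, and its steps to compound 2 and compound 3 cannot be read: the limit of < 13 mL/min/kg in the Homo sapiens assay, at which 1 of the 3 values shown sits. What remains open is how a methyl, a trifluoromethyl or a nitrile on this aromatic carbon would behave, and whether clearance would still hold steady with a group that moves the distribution coefficient further than chloro does here.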